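The source may report more compounds than this note shows. Statements on the series, on what has been measured and on what is new or still open speak of the compounds shown alone.

Compounds measured so far:
compound 1, `Brc1cncc(OC[C@@H]2CCN2)c1` — in an assay on brain for binding affinity to Neuronal acetylcholine receptor; alpha4/beta2 (Rattus norvegicus), read by radioligand binding (a lower number here means a stronger inhibitor, a higher number a weaker inhibitor), compound 1 gives 0.18 nM
compound 2, `NCc1cncc(OC[C@@H]2CCN2)c1` — in this assay compound 2 gives 4.4 nM

Compound 2 holds the highest number of the two in this assay; its nearest neighbour is compound 1, and the step of a 24-fold higher number from compound 1 to compound 2 (1.39 log units; beyond the scatter) sets the two apart. The only structural difference behind that step is the aminomethyl in place of bromo on an aromatic carbon of the shared core.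

Compound 3, `c1ccc(-c2cncc(OC[C@@H]3CCN3)c2)cc1`, has not yet been measured in this assay. It differs from compound 2 by phenyl in place of aminomethyl on an aromatic carbon. Within the data shown here, one measured step bears on this change: a 24-fold higher number from compound 1 to compound 2 (1.39 log units; beyond the scatter), which shows that the core with bromo at that aromatic carbon gives a far lower number than the core with aminomethyl there. Among the measured compounds shown here, compound 3 again carries a group with no hydrogen-bond donor or acceptor at that same place, so a lower number than that of compound 2 is expected, with a step of an 8.8-fold lower number from compound 2 to compound 3 (0.94 log units; beyond the scatter), though the phenyl is larger than bromo and no measured compound tells how size alone acts here. For compound 3 the estimate in this assay is 0.5 nM, with a range from 0.1 nM to 3 nM.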

Compound 3, inhibition constant: 0.046 nM
For compound 3 the middle estimate is 11-fold (1.04 log units) above the measured one; measured number outside the range, below it.
By their numbers in this assay, from the lowest: compound 3; then compound 1; then compound 2.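

Replacing the aminomethyl group with phenyl on this aromatic carbon, two atoms from the ring nitrogen, gives the largest change seen so far in this assay (a 96-fold lower number from compound 2 to compound 3 (1.98 log units; beyond the scatter)). The earlier pair showed only that bromo gives a lower number than aminomethyl here, whereas the new result shows that a six-membered aromatic ring of 6 heavy atoms can go further still (a 3.9-fold lower number from compound 1 to compound 3 (0.59 log units; beyond the scatter)), so among these three compounds the larger group at this place does not cost affinity, and the order from lowest to highest number is phenyl, bromo, aminomethyl. No measurement shown here accounts for either step, so the data give the order of the three groups and no reason for it.

The three compounds leave open whether the high number of compound 2 belongs to its amine or to its one-carbon chain, which a methyl or hydroxymethyl group at the same place would help to separate. They also leave open how far the low number of compound 3 survives on the ring itself, for instance with a methoxy group or chlorine on the phenyl, or with a pyridine ring in its place.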